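This account rests on a few compounds, and the source may have more. Where it says the series, first, only, none or still open, it means among the compounds named here.

Measured compounds:
compound 1, `COc1cc(/C=C/c2nnc(NC(=O)c3ccccc3Br)s2)c(Br)c(OC)c1OC` — 370 nM
compound 2, `COc1ccc(/C=C/c2nnc(NC(=O)c3cc(OC)c(OC)c(OC)c3Br)s2)cc1` — 550 nM

In a functional assay on MCF7 cells (Homo sapiens) for antiproliferative activity, read by MTT assay, with a stated time of 48 h (on this read-out lower numbers stand for stronger inhibition and higher numbers for weaker inhibition), compound 1 gives the lower of the two numbers, and compound 2 sits close by at a number within the scatter, so neither can be called the stronger. Compound 3, `COc1cc(/C=C/c2nnc(NC(=O)c3ccccc3)s2)c(Br)c(OC)c1OC`, differs from compound 1 in one place: hydrogen in place of bromo on an aromatic carbon — read one bond further out, 2-bromophenyl becomes phenyl. Among the measured compounds shown here, no measured pair shows this change, so the account expects little beyond the scatter, a 1.2-fold higher number from compound 1 to compound 3 (0.09 log units; within the scatter), perhaps slightly toward a higher number. Compound 3 is therefore estimated at 450 nM, with a range from 200 nM to 1100 nM.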

Compound 3, half-maximal inhibitory concentration: 290 nM
Estimate against measurement, compound 3: 1.6-fold (0.19 log units) above, within the range that was stated.
By their numbers in this assay, from the lowest: compounds 3, 1 and 2 (each within the scatter of the next).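

In this assay the first pair differing in one place shows a 1.3-fold lower number from compound 1 to compound 3 (0.11 log units; within the scatter) as the size of this step, so the 2-bromophenyl and phenyl forms cannot be told apart on this read-out. At this position, on an aromatic carbon ortho to a large group, compound 1 therefore does not depend on its bromo for its number here. Nothing shown gives a reason for this result. As far as these compounds go, whether an amine or a carboxylic acid at this position would leave the number within the scatter remains open. So does whether hydrogen in place of bromo would give a similar step in compound 2.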